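The source may hold more compounds than are shown below. What is called first, only, known or untested is meant among the compounds shown, and "the series" means these compounds.

- Compound 1 `CC(C)C(c1ccc(-c2ccc3cccc(F)c3c2)[nH]c1=O)C1NC(=O)NC1=O`: 0.145 h
- Compound 2 `O=C1NC(=O)/C(=C/C(c2ccc(-c3ccc4cccc(F)c4c3)[nH]c2=O)C2CCCC2)O1`: > 3 h (a limit)

Among the measured compounds shown here, in an ADME assay on microsomes from liver (Rattus norvegicus) for metabolic stability (a lower number here means that the compound disappears faster, a higher number that the compound lasts longer), compound 1 gives 0.145 h, the only exact number so far. The reading for compound 2, > 3 h, is a limit of the assay and not a number. Compound 3 `CC(C)C(/C=C1/C(=O)NC(=O)N1C)c1ccc(-c2ccc3cccc(F)c3c2)[nH]c1=O` keeps the core of compound 1 but changes the group on a saturated chain carbon bound to an aromatic carbon and a saturated chain carbon: a group of 9 heavy atoms (5 carbon, 2 nitrogen, 2 oxygen; one five-membered non-aromatic ring with 2 hetero atoms) in place of a group of 7 heavy atoms (3 carbon, 2 nitrogen, 2 oxygen; one five-membered non-aromatic ring with 2 hetero atoms), on a saturated chain carbon bound to an aromatic carbon and a saturated chain carbon. For the measured compounds named here, no measured step shows this change, but compound 2, with its limit of > 3 h, suggests a longer half-life in this assay. The expected change is a 6.9-fold higher number from compound 1 to compound 3 (0.84 log units; beyond the scatter), beyond the scatter. Compound 3 is estimated at 1 h, within a range of 0.3 h to 3.5 h.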

Compound 3, half-life: 1.08 h
The estimate for compound 3 lay 1.1-fold (0.03 log units) below the measured number, within the range that was stated.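

In this assay putting the larger group of compound 3 in place of 2,5-dioxoimidazolidin-4-yl gives a 7.4-fold higher number from compound 1 to compound 3 (0.87 log units; beyond the scatter) at the saturated chain carbon bound to an aromatic carbon and a saturated chain carbon. This first measured step at this position shows that the half-life responds to the group placed there while the core stays the same. Among the compounds shown here, the single step changes the heavy atoms, the double bonds and the hydrogen-bond donors together, and it cannot say which of these matters.

As far as these compounds go, whether an amine or a carboxylic acid at this position would last as long remains open. Compound 2 gives only a limit of the assay and not a number: the limit of > 3 h in this assay, at which 1 of the 3 values shown sits.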